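The compounds below may be only part of what the source reports. "The series", "measured", "known", "first", "only" and "open" are said of these compounds alone.

Working notes on the series, read in a functional assay on MCF7 cells (Homo sapiens) for antiproliferative activity, read by MTT assay, with a stated time of 72 h; on this read-out lower numbers stand for stronger inhibition and higher numbers for weaker inhibition. Compound 3 `C=CC(=O)Nc1cccc(Oc2nc(Nc3cccc(OC)c3)nc3c2CSCC3)c1` has only a limit, > 50000 nM, so its position is not a number. Compound 1 `C=CC(=O)Nc1cccc(Oc2nc(Nc3ccn(C)n3)nc3c2CSCC3)c1` also has only a limit, > 50000 nM. These two compounds make up (the limit of > 50000 nM in this assay, at which 2 of the 3 values shown sit). Compound 2 `C/C=C/C(=O)Nc1cccc(Oc2nc(Nc3ccn(C)n3)nc3c2CSCC3)c1` gives a number, 40000 nM.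

Compound 4 `C/C=C/C(=O)Nc1cccc(Oc2nc(Nc3cccc(OC)c3)nc3c2CSCC3)c1` has prop-1-en-1-yl in place of vinyl on a carbonyl carbon. The same exchange has been measured once, as an at least 1.2-fold lower number from compound 1 to compound 2 (0.09 log units; that floor lies within the scatter). That floor lies within the scatter. Compound 1 is held at a limit. On these data alone, the true size of the step remains open. The other measured step, a step that the two limits leave unreadable from compound 1 to compound 3, cannot be read, so it does not show whether the exchange carries over to the 3-methoxyphenyl compounds. No step beyond the scatter is therefore expected in this assay, with any shift tending towards a lower number, as with compound 2 at 40000 nM.

An estimated at least 1.1-fold lower number from compound 3 to compound 4 (0.04 log units; that floor lies within the scatter) is expected. Compound 4 is estimated at 45000 nM, with an expected range of 25000 nM to 70000 nM.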

Compound 4, half-maximal inhibitory concentration: 23400 nM
For compound 4 the middle estimate is 1.9-fold (0.28 log units) above the measured one, and the stated range ends above it.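

In this assay, prop-1-en-1-yl in place of vinyl on a carbonyl carbon now gives a floor beyond the scatter, an at least 2.1-fold lower number from compound 3 to compound 4 (0.32 log units; beyond the scatter), whereas the earlier floor for this change lay within it. The two results for this change cannot yet be told apart in size: the same change on two cores in this assay, an at least 1.2-fold lower number (0.09 log units; that floor lies within the scatter) from compound 1 to compound 2 and an at least 2.1-fold lower number (0.32 log units; beyond the scatter) from compound 3 to compound 4; the limit leaves it open whether they differ. Within the data shown here, with prop-1-en-1-yl held constant, the exchange of 1-methyl-1H-pyrazol-3-yl for 3-methoxyphenyl on a nitrogen on an aromatic ring becomes readable for the first time, and it stays within the scatter, a 1.7-fold lower number from compound 2 to compound 4 (0.23 log units; within the scatter).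

On these data alone, the true sizes of the steps from compound 1 and compound 3 stay open: the limit of > 50000 nM in this assay, at which 2 of the 4 values shown sit. Also open, as far as these compounds go, is how a longer chain or an amine-bearing chain in place of prop-1-en-1-yl would read in this assay.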